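A few compounds are considered here, and "the series" means these few. Any claim that something is new, unique, unknown or untested is made for them only; others in the source may bear on it.

In an ADME assay on BV-2 cells (Mus musculus) for cytotoxicity, with a stated time of 24 h, tested at 50 uM (a higher number here means a weaker effect of the compound at the concentration tested, a lower number a stronger effect), the three measured compounds gave these numbers:

compound 1, `COc1ccccc1S(=O)(=O)/C=C/c1cncnc1`: 97.9%
compound 2, `COc1ccccc1/C=C/S(=O)(=O)c1ccccn1`: 93.4%
compound 3, `O=S(=O)(/C=C/c1ccccc1F)c1ccccn1`: 98.6%

Compound 3 sits within the scatter of both others: compound 1 gives 97.9% and compound 2 gives 93.4%, and all three numbers point to weak effects at the tested concentration. Compound 4, `O=S(=O)(/C=C/c1ccccc1F)c1ncccc1C(F)(F)F`, differs from compound 3 by trifluoromethyl in place of hydrogen on an aromatic carbon. Among the measured compounds shown here, the only measured step, a number 5.2 percentage points higher from compound 2 to compound 3 (within the scatter), concerns a different change on the other ring, and no step with trifluoromethyl in place of hydrogen is available, so no step beyond the scatter is expected in this assay for compound 4. Compound 4 is therefore estimated to give 96%, a step of a number 2.6 percentage points lower from compound 3 to compound 4 (within the scatter), with a range of 87% to 100%.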

Compound 4, a percentage reported as activity, at one concentration (the size of the read-out at that concentration, not a potency): 100%
Beside the measured number, compound 4's estimate is 4 percentage points below it; measured number inside the range.
By their numbers in this assay, from the lowest: compounds 2, 1, 3 and 4 (each within the scatter of the next).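

In this assay, among the compounds shown here, the ring carrying the nitrogen proves open to substitution for the first time: trifluoromethyl in place of hydrogen, on an aromatic carbon two atoms from the ring nitrogen and ortho to a large group, gives a number 1.4 percentage points higher from compound 3 to compound 4 (within the scatter). Adding these four heavy atoms at this position therefore leaves the read-out unchanged within the scatter. No measured evidence bears on this result.

As far as these compounds go, what remains open is whether an amine or a carboxylic acid on the same aromatic carbon would also stay within the scatter.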